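This account rests on a few compounds, and the source may have more. Where it says the series, first, only, none or still open, it means among the compounds named here.

Measured compounds in a functional assay on MDA-MB-468 cells (Homo sapiens) for inhibition, read by sulforhodamine B assay, with a stated time of 48 h; on this read-out lower numbers stand for higher toxicity in this test and higher numbers for lower toxicity in this test:
compound 1 `COc1cc(-c2cc(/C=C/C(=O)c3ccc(N)cc3)[nH]n2)cc(OC)c1OC` gives 8420 nM
compound 2 `COc1ccc(C(=O)/C=C/c2cc(-c3cc(OC)c(OC)c(OC)c3)n[nH]2)cc1OC` gives 5210 nM

Going by the values given here, the two numbers do not separate: the step of a 1.6-fold lower number from compound 1 to compound 2 (0.21 log units; within the scatter) is within the scatter, so compound 2 cannot be told apart from compound 1 on this read-out, and no ranking of the pair is warranted. Compound 3 `COc1cc(C(=O)/C=C/c2cc(-c3cc(OC)c(OC)c(OC)c3)n[nH]2)cc(OC)c1OC` has not been measured. It differs from compound 2 by methoxy in place of hydrogen on an aromatic carbon. Among the compounds with values here, only one measured step is available, a 1.6-fold lower number from compound 1 to compound 2 (0.21 log units; within the scatter), and it concerns a different change, the exchange of one aryl for another on a carbonyl carbon, not the addition of a methoxy group; a direct precedent for the present change is absent. Given that the single known step stays within the scatter, no move beyond the scatter is expected here, and the step of a 1.0-fold lower number from compound 2 to compound 3 (0.02 log units; within the scatter) is set accordingly. The expected value for compound 3 in this assay is 5000 nM, with a range from 2000 nM to 12000 nM.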

Compound 3, concentration lethal to 50% of the cells: 5370 nM
Estimate against measurement, compound 3: 1.1-fold (0.03 log units) below, and the stated range covers the measured number.
By their numbers in this assay, from the lowest: compounds 2, 3 and 1 (each within the scatter of the next).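

In this assay, methoxy in place of hydrogen on an aromatic carbon, ortho to a methoxy group and meta to a large group, gives a 1.0-fold higher number from compound 2 to compound 3 (0.01 log units; within the scatter) and so produces no separable change at this position. The earlier pair addressed only the exchange of one aryl for another on a carbonyl carbon, whereas this step tests a single added group on the aromatic ring and shows that methoxy is accepted here on this read-out. No available evidence bears on this result.

As far as these compounds go, whether an amine, a hydroxyl group or a fluorine atom at this position would move the number beyond the scatter remains open. Also open, from the compounds shown here alone, is whether a longer alkoxy chain here would behave as methoxy does.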